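Removing the benzoyl group from compound 2

The source may hold more compounds than are shown below. What is called first, only, known or untested is meant among the compounds shown, and "the series" means these compounds.

Compound 2 `O=C(Nc1ccc(-n2ccc3c(NC(=O)c4ccccc4)ncnc32)cc1)c1ccc(Cl)c(C(F)(F)F)c1` was tested in a functional assay on A375P cells (Homo sapiens) for antiproliferative activity, read by MTT assay, with a stated time of 24 h (on this read-out higher numbers stand for weaker inhibition and lower numbers for stronger inhibition), where compound 2 gives 2300 nM. Its only measured relative, compound 1 `O=C(Nc1ccc(-n2ccc3c(NC(=O)c4ccccc4)ncnc32)cc1)Nc1ccc(Cl)c(C(F)(F)F)c1`, gives 4600 nM in this assay, and the two numbers lie within the usual scatter of each other, so compound 2 stands apart from compound 1 only by the change at the urea end, a 2.0-fold lower number from compound 1 to compound 2 (0.30 log units; within the scatter).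

Compound 3 `Nc1ncnc2c1ccn2-c1ccc(NC(=O)c2ccc(Cl)c(C(F)(F)F)c2)cc1` differs from compound 2 in a different place: hydrogen in place of benzoyl on a nitrogen on an aromatic ring. Within the data shown here, no measured pair touches this position, so the one known step, which concerns the far end of the molecule and is itself within the scatter, gives little guidance. The working expectation is therefore no step beyond the scatter, carried with wide uncertainty, as a 1.3-fold higher number from compound 2 to compound 3 (0.12 log units; within the scatter). Compound 3 is estimated at 3000 nM, within a range from 600 nM to 15000 nM.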

Compound 3, half-maximal inhibitory concentration: 2900 nM
Beside the measured number, compound 3's estimate is 1.0-fold (0.01 log units) above it, within the range that was stated.
By their numbers in this assay, from the lowest: compounds 2, 3 and 1 (each within the scatter of the next).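

Among these compounds, until now, the only change seen was at the urea end of the molecule; this result is the first to probe the nitrogen at the other end. In this assay, cutting the benzoyl group back to hydrogen, so that benzamido becomes amino, gives a 1.3-fold higher number from compound 2 to compound 3 (0.10 log units; within the scatter) and removes an entire aromatic ring and a carbonyl. The benzamido and amino forms therefore cannot be told apart on this read-out, so the benzoyl group is not required for a number of this size, and no available measurement explains why the two compounds read alike.

From the compounds shown here alone, whether an acetyl group or a longer chain such as hexanoyl on this nitrogen would move the number beyond the scatter remains open. So does whether an amine-bearing chain there would behave any differently.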